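The source may hold more compounds than are shown below. What is called first, only, known or untested is meant among the compounds shown, and "the series" means these compounds.

Measured compounds:
compound 1: `Cc1cc(NCc2ccccn2)n2ncc(-c3cc(F)c(F)c(F)c3)c2n1` — < 5000 nM in a physicochemical assay for solubility, read by HPLC, using the shake flask method, measured as kinetic solubility, with a stated time of 2 h, at pH 7.4; a higher number here means a more soluble compound, a lower number a less soluble compound
compound 2: `Cc1cc(NCc2ccccn2)n2ncc(-c3ccc(O)cc3)c2n1` — 10900 nM in this assay

Compound 1 gives only a limit in this assay, namely < 5000 nM. That limit is the limit of < 5000 nM in this assay, at which 1 of the 2 values shown sits. Among the measured compounds shown here, compound 2 stands at 10900 nM, the only actual number among the two values shown. For the measured compounds named here, the step of an at least 2.1-fold higher number from compound 1 to compound 2 (0.33 log units; beyond the scatter) is the single measured step, and it runs from a limit to a number, so its true size is known only as a lower bound.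

Compound 3 `Cc1cc(NCc2ccccn2)n2ncc(-c3cccc(N)c3)c2n1` differs from compound 2 in one place: 3-aminophenyl in place of 4-hydroxyphenyl on an aromatic carbon. Going by the values given here, no measured step exchanges one of these two groups for the other. Among the compounds with values here, the one step at hand, an at least 2.1-fold higher number from compound 1 to compound 2 (0.33 log units; beyond the scatter), concerns the arrival of the 4-hydroxyphenyl group itself and says little about the move from 4-hydroxyphenyl to 3-aminophenyl, where the counted donors and acceptors stay the same.

He therefore expects for compound 3 a step of a 1.1-fold higher number from compound 2 to compound 3 (0.04 log units; within the scatter) that stays within the scatter, and estimates compound 3 at 12000 nM, between 5000 nM and 30000 nM.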

Compound 3, solubility: 160000 nM
Compound 3: middle estimate off by 13-fold (1.12 log units), on the low side; measured number outside the range, above it.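

The earlier compounds shown here showed a step only for the arrival of the 4-hydroxyphenyl group, whereas here, in this assay, a second group at the same aromatic carbon gives a 15-fold higher number from compound 2 to compound 3 (1.17 log units; beyond the scatter). The exchange of 4-hydroxyphenyl for 3-aminophenyl therefore moves the read-out by a large amount, even though the heavy atoms, the counted donors and acceptors and the net charge stay the same, so those counts alone do not capture what this position responds to. Measured against 3,4,5-trifluorophenyl, the same group gives an at least 32-fold higher number from compound 1 to compound 3 (1.50 log units; beyond the scatter), and this step is only a lower bound, as compound 1 gives a limit and not a number: the limit of < 5000 nM in this assay, at which 1 of the 3 values shown sits.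

Both the atom and its place on the phenyl ring change at once between compound 2 and compound 3, so these compounds cannot tell whether the step follows the amine itself or where it sits. They also leave open how an amide, a carboxylic acid or a longer aminoalkyl chain on that phenyl ring would read in this assay.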